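Swapping the para substituent on a shared nitropyrimidine ether core

The compounds below may be only part of what the source reports. "The series", "measured", "known", "first", "only" and "open" are said of these compounds alone.

Compound 1 `CCOC(=O)C1CCN(c2ncnc(Oc3ccc(C(=O)CC(=O)OC)cc3)c2[N+](=O)[O-])CC1` gives 1000 nM in a functional assay on HEK293 cells for agonist activity at Glucose-dependent insulinotropic receptor (Homo sapiens), read by cAMP accumulation; a lower number here means that less compound is needed, a higher number that more compound is needed for the effect. Compound 2 `CCOC(=O)C1CCN(c2ncnc(Oc3ccc(S(N)(=O)=O)cc3)c2[N+](=O)[O-])CC1` gives 3000 nM.

For the measured compounds named here, compound 2 stands at the highest of the two numbers; the only measured step, a 3.0-fold higher number from compound 1 to compound 2 (0.48 log units; beyond the scatter), separates it from compound 1. Compound 3 `CCOC(=O)C1CCN(c2ncnc(Oc3ccc(-n4cncn4)cc3)c2[N+](=O)[O-])CC1` carries the change (1H-1,2,4-triazol-1-yl in place of sulfamoyl on an aromatic carbon). Going by the values given here, no measured step involves a triazolyl group, so only the modest size of the one step at this position guides the expectation. A step of a 1.5-fold lower number from compound 2 to compound 3 (0.18 log units; within the scatter) is therefore expected, with wide uncertainty. Compound 3 is estimated at 2000 nM, in the range 500 nM to 8000 nM.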

Compound 3, half-maximal effective concentration: 2500 nM
Estimate against measurement, compound 3: 1.3-fold (0.10 log units) below; measured number inside the range.
By their numbers in this assay, from the lowest: compound 1; then compounds 3 and 2 (each within the scatter of the next).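

In this assay, 1H-1,2,4-triazol-1-yl in place of sulfamoyl gives a 1.2-fold lower number from compound 2 to compound 3 (0.08 log units; within the scatter), so this position does not separate these two groups, although their rings and hydrogen-bond counts differ. The ((methoxycarbonyl)methyl)carbonyl group stays apart from the triazolyl group too, with a 2.5-fold higher number from compound 1 to compound 3 (0.40 log units; beyond the scatter) on the shared core. No available evidence bears on this result. Going by these compounds, what a simple amine or a carboxylic acid would give at this position remains open, and so does whether a longer chain there would give a lower number than compound 1 does.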